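This account rests on a few compounds, and the source may have more. Where it says the series, first, only, none or still open, it means among the compounds named here.

The measured compounds are compound 1 `CCOC(=O)c1[nH]c(=O)c(C#N)cc1C(=O)c1ccccc1` and compound 2 `CCOC(=O)c1[nH]c(=O)c(C#N)cc1C(=O)c1ccc(F)cc1`. In an ADME assay on L929 cells (Mus musculus) for cytotoxicity, read by MTT assay, with a stated time of 72 h (on this read-out higher numbers stand for lower toxicity in this test and lower numbers for higher toxicity in this test), compound 1 gives 465000 nM. In this assay compound 2 gives 232000 nM. Within the data shown here, compound 2 stands beside the only other measured compound with the two numbers within the usual scatter of each other: the single step of the set, a 2.0-fold lower number from compound 1 to compound 2 (0.30 log units; within the scatter), separates them.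

Compound 3 `CCOC(=O)c1[nH]c(=O)c(C#N)cc1C(=O)c1ccc(OC)cc1` is still unmeasured. It differs from compound 2 in one place: methoxy in place of fluoro on an aromatic carbon. Among the measured compounds shown here, no measured step bears directly on this exchange. For the measured compounds named here, the one step of the set concerns fluoro in place of hydrogen on an aromatic carbon, and that step, a 2.0-fold lower number from compound 1 to compound 2 (0.30 log units; within the scatter), was within the scatter. The data therefore give no ground for a step beyond the scatter in this assay in either direction. For compound 3 the expected step is a 1.3-fold higher number from compound 2 to compound 3 (0.11 log units; within the scatter). Compound 3 is estimated at 300000 nM in this assay, with an expected range from 100000 nM to 900000 nM.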

Compound 3, half-maximal cytotoxic concentration: 259000 nM
Beside the measured number, compound 3's estimate is 1.2-fold (0.06 log units) above it; measured number inside the range.
By their numbers in this assay, from the lowest: compounds 2, 3 and 1 (each within the scatter of the next).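

Replacing fluoro with methoxy, the 4-fluorophenyl to 4-methoxyphenyl exchange on an aromatic carbon para to a large group, gives a 1.1-fold higher number from compound 2 to compound 3 (0.05 log units; within the scatter) in this assay, so the larger group with its hydrogen-bond acceptor does not separate the two compounds on this read-out. Measured against hydrogen at the same place, methoxy gives a 1.8-fold lower number from compound 1 to compound 3 (0.25 log units; within the scatter), so this position now carries two different groups, fluoro and methoxy, and neither step from the unsubstituted compound leaves the scatter. Among these compounds, no accompanying measurement offers an explanation for these results, and the data show only that the three numbers cannot be told apart in this test.

Whether an amine, a carboxylic acid or a longer chain such as butoxy at this same place would produce a step beyond the scatter remains open, as fluoro and methoxy are the only groups shown there. Also open, on these data alone, is how this read-out responds to a group on another carbon of that aromatic ring, or to a replacement of the ethyl ester on the shared core.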